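This account rests on a few compounds, and the source may have more. Where it says the series, first, only, none or still open, it means among the compounds named here.

Working notes on a pair of hydantoin-type analogues measured in a functional assay on MCF7 cells (Homo sapiens) for inhibition; on this read-out lower numbers stand for stronger inhibition and higher numbers for weaker inhibition. Compound 1 `CCC(C)C1NC(=O)N(C2CCCCC2)C1=O` gives 94300 nM, the highest of the two numbers available. The only comparator, compound 2 `O=C1NC(c2ccccc2)C(=O)N1Cc1ccccc1`, gives 3300 nM, a number a good deal lower than that of compound 1; the two differ in several places at once, so no single step can be read from them.

For the measured compounds named here, compound 3 `CC(C)C1NC(=O)N(C2CCCCC2)C1=O` is the one analogue still to be measured. Relative to compound 1 the change is hydrogen in place of methyl on a saturated chain carbon, two bonds along the chain from a saturated ring carbon, that is, sec-butyl to isopropyl, one carbon shorter on the side chain.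

Going by the values given here, no measured step of this kind exists. The expected step in this assay is small, and a change beyond the scatter is not anticipated in either direction; if anything a slightly higher number is expected, since the change only removes a carbon from a chain on a compound that already stands weakest. For compound 3 the expected step is a 1.2-fold higher number from compound 1 to compound 3 (0.07 log units; within the scatter), giving an estimated 110000 nM with a range from 45000 nM to 270000 nM.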

Compound 3, half-maximal inhibitory concentration: > 100000 nM
Compound 3 ended at the assay's limit (the forecaster's own chance of this, stated with the estimate: 30%); the middle value does not contradict the limit.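

For the compounds shown here, this is the first reading of a change in one place only: sec-butyl to isopropyl on the shared core gives an at least 1.0-fold higher number from compound 1 to compound 3 (0.02 log units; that floor lies within the scatter) in this assay and supplies a floor, not a measured size. Compound 3 gives > 100000 nM as its result, and this is a limit of the assay, not a number. Removing this methyl therefore shows no gain in this assay, while the true size of the step stays unresolved and the reading at this position is bounded by the limit: the limit of > 100000 nM in this assay, at which 1 of the 3 values shown sits.

Still open, going by these compounds, is whether a longer chain at this place would bring the number down from the limit. Equally open, on these data alone, is how an amine or a carboxylic acid on this side chain would read in this assay on the core of compound 1.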